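Compound 2 to compound 3: methyl to 4-bromobenzyl

A few compounds are considered here, and "the series" means these few. Any claim that something is new, unique, unknown or untested is made for them only; others in the source may bear on it.

Compound 1 `CN1C(=O)C(O)(Cc2nnn[nH]2)c2ccccc21`: 36800 nM
Compound 2 `CN1C(=O)C(O)(Cc2nnn[nH]2)c2cc(F)ccc21`: > 100000 nM

In a functional assay on DU-145 cells (Homo sapiens) for antiproliferative activity, read by MTT assay, with a stated time of 48 h (a lower number here means a stronger inhibitor, a higher number a weaker inhibitor), compound 1 gives 36800 nM. Compound 2 gives > 100000 nM, which is a limit of the assay and not a number. Within the data shown here, the only measured step, an at least 2.7-fold higher number from compound 1 to compound 2 (0.43 log units; beyond the scatter), is fluoro in place of hydrogen on an aromatic carbon.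

Compound 3 `O=C1N(Cc2ccc(Br)cc2)c2ccc(F)cc2C1(O)Cc1nnn[nH]1` differs from compound 2 elsewhere: 4-bromophenyl in place of hydrogen on a saturated chain carbon bound to an amide-type nitrogen in a ring. This is 4-bromophenyl in place of hydrogen on a saturated chain carbon bound to an amide-type nitrogen in a ring. Among the measured compounds shown here, no measured step covers that place, so the size of the change is poorly constrained. Since compound 2 stands at the limit of > 100000 nM in this assay, at which 1 of the 2 values shown sits, a lower number is expected in this assay, with a modest step as the working guess. The expected step is an at least 3.3-fold lower number from compound 2 to compound 3 (0.52 log units; beyond the scatter). For compound 3 the estimate is 30000 nM, with an expected range of 8000 nM to 100000 nM.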

Compound 3, half-maximal inhibitory concentration: 14400 nM
For compound 3 the middle estimate is 2.1-fold (0.32 log units) above the measured one; the range from low to high includes it.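

In this assay, the saturated chain carbon bound to an amide-type nitrogen in a ring proves to be a place where the series responds: the change from methyl to 4-bromobenzyl gives an at least 6.9-fold lower number from compound 2 to compound 3 (0.84 log units; beyond the scatter). The earlier step at the aromatic carbon had only raised the number, whereas this change on the fluoro compound brings compound 3 to a measured 14400 nM. The true size of the step remains unknown because compound 2 stands at a limit of the assay: the limit of > 100000 nM in this assay, at which 1 of the 3 values shown sits.

As far as these compounds go, whether the step comes from the bromine or from the phenyl ring stays open, as does whether a plain benzyl or a 4-methoxybenzyl would behave alike. From the compounds shown here alone, it is also open whether 4-bromobenzyl would give a similar step on the core of compound 1, which carries hydrogen in place of fluoro.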